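The source may hold more compounds than are shown below. What is called first, only, known or untested is meant among the compounds shown, and "the series" means these compounds.

Of the compounds shown here, three built on one shared core have been measured in a functional assay on MKN-45 cells (Homo sapiens) for cytotoxicity, read by MTT assay, with a stated time of 72 h; on this read-out higher numbers stand for weaker inhibition and lower numbers for stronger inhibition. Compound 1 `COc1ccc(-c2ccnc(C(=O)Nc3ccc(Oc4ccnc5cc(OCCCN6CCN(C)CC6)c(OC)cc45)c(F)c3)c2)cc1` gives 250 nM. Within the data shown here, compound 2 `COc1ccc(-c2ccnc(C(=O)Nc3ccc(Oc4ccnc5cc(OCCCN6CCN(C)CC6)c(OC)cc45)c(F)c3)c2)c(OC)c1` gives 330 nM, and the single step between them, a 1.3-fold higher number from compound 1 to compound 2 (0.12 log units; within the scatter), comes from a methoxy in place of hydrogen on an aromatic carbon. Compound 3 `COc1cc2c(Oc3ccc(NC(=O)c4cc(-c5ccc(C)cc5)ccn4)cc3F)ccnc2cc1OCCCN1CCCC1` gives 440 nM, the highest of the three numbers shown, though its gaps to compound 2 and to compound 1 both lie within the scatter. Compound 4 `COc1cc2c(Oc3ccc(NC(=O)c4cc(-c5ccc(C(F)(F)F)cc5)ccn4)cc3F)ccnc2cc1OCCCN1CCCC1` differs from compound 3 by trifluoromethyl in place of methyl on an aromatic carbon. Among the measured compounds shown here, no measured step touches this change, and the one step known stayed within the scatter, so no shift beyond the scatter in this assay is expected in either direction. Compound 4 is therefore estimated at 440 nM, with a range from 150 nM to 1300 nM, meaning an expected step of no change at the digits printed from compound 3 to compound 4 (within the scatter).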

Compound 4, half-maximal inhibitory concentration: 260 nM
Beside the measured number, compound 4's estimate is 1.7-fold (0.23 log units) above it; measured number inside the range.
By their numbers in this assay, from the lowest: compounds 1, 4, 2 and 3 (each within the scatter of the next).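

In this assay the change from 4-methylphenyl to 4-(trifluoromethyl)phenyl gives a 1.7-fold lower number from compound 3 to compound 4 (0.23 log units; within the scatter) and so adds the first step read at this aromatic carbon. At this position, on these two compounds, three more heavy atoms in the group leave the number within the scatter. No measured evidence on these compounds bears on this result.

Still open, going by these compounds, is whether an amine, a carboxylic acid or a longer chain on this same aromatic carbon would also stay within the scatter. Also open, on these data alone, is whether trifluoromethyl would do so on the side chain of compound 1.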